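This account rests on a few compounds, and the source may have more. Where it says the series, first, only, none or still open, it means among the compounds named here.

Of the compounds shown here, three from this set have been measured in a functional assay, with stated times of 30 s and 6 min, in the presence of a further agent that is not named here; a lower number here means a stronger inhibitor, a higher number a weaker inhibitor. Compound 1 has the structure `CCCCCCCCCCCCOc1cc(OC)c(Br)cc1C(C)=O` and in this assay gives 10600000 nM. Compound 2, with the structure `CCCCCCCCCCCCCCOc1cc(OC)c(Br)cc1C(C)=O`, gives 6800000 nM in this assay. The two differ by one change, described as ethyl in place of hydrogen on a saturated chain carbon, ten or more bonds along the chain from an oxygen on an aromatic ring, and the result is a 1.6-fold lower number from compound 1 to compound 2 (0.19 log units; within the scatter). Compound 3 has the structure `CCCCCCCCCCCCCCOc1cc(OC)ccc1C(C)=O` and in this assay gives 35900000 nM, the highest number among the three; from compound 2 to compound 3 the change is hydrogen in place of bromo on an aromatic carbon, and the step is a 5.3-fold higher number from compound 2 to compound 3 (0.72 log units; beyond the scatter). The difference between the core of compound 1 and the core of compound 3 is not broken down here.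

Compound 4, with the structure `CCCCCCCCCCCCCCCCOc1cc(OC)ccc1C(C)=O`, has not yet been measured. It differs from compound 3 by ethyl in place of hydrogen on a saturated chain carbon, ten or more bonds along the chain from an oxygen on an aromatic ring, and since the place of this change is described in exactly the same words as the change from compound 1 to compound 2, it is the same change, made this time on the core of compound 3. Going by the values given here, on the basis of the single earlier example, where lengthening the chain produced a step that stayed within the scatter, the step from compound 3 to compound 4 is expected to be of similar size, a 1.6-fold lower number from compound 3 to compound 4 (0.19 log units; within the scatter), which would leave compound 4 still a very weak inhibitor. Compound 4 is therefore estimated to give about 23000000 nM in this assay, most likely falling between 10000000 nM and 50000000 nM.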

Compound 4, half-maximal inhibitory concentration: 39400000 nM
Compound 4: the middle estimate sits 1.7-fold (0.23 log units) below what was measured; the measured number falls inside the stated range.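

In this assay, putting ethyl in place of hydrogen on a saturated chain carbon, ten or more bonds along the chain from an oxygen on an aromatic ring, gives a 1.1-fold higher number from compound 3 to compound 4 (0.04 log units; within the scatter). Set beside the earlier example, the change behaves alike on the two cores, since neither step leaves the usual scatter and the two steps cannot be told apart: the same change on two cores in this assay, a 1.6-fold lower number (0.19 log units; within the scatter) from compound 1 to compound 2 and a 1.1-fold higher number (0.04 log units; within the scatter) from compound 3 to compound 4, 1.7-fold (0.23 log units) apart, within the scatter of two such steps This shows that, in these two pairs, the longer chain leaves the inhibitory number essentially where it was, so no real gain or loss can be read from it, and the opposite directions of the two steps carry no meaning; it does not show that the same would hold on any other core or at any other chain length.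

Going by these compounds alone, the one clear step in this set is a 5.3-fold higher number from compound 2 to compound 3 (0.72 log units; beyond the scatter), and it is seen on a single chain, so it remains open whether swapping bromo for hydrogen would do the same on another chain, or what a different group there, such as chloro or a nitrile, would do. Also open, on these data alone, is whether a much shorter chain, or a chain ending in an amine or a carboxylic acid, would move the number beyond the scatter.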